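A few compounds are considered here, and "the series" means these few. Any claim that something is new, unique, unknown or untested is made for them only; others in the source may bear on it.

- Compound 1 `CC[C@H](C)[C@@H](NC(=O)Cn1cc(C2=C(c3c[nH]c4ccccc34)C(=O)N(C)C2=O)c2ccccc21)C(=O)OC`: > 100000 nM, a limit of the assay
- Compound 2 `COC(=O)[C@H](NC(=O)Cn1cc(C2=C(c3c[nH]c4ccccc34)C(=O)N(C)C2=O)c2ccccc21)[C@@H](C)O`: 25700 nM
- Compound 3 `COC(=O)CCNC(=O)Cn1cc(C2=C(c3c[nH]c4ccccc34)C(=O)N(C)C2=O)c2ccccc21`: 37600 nM
- Compound 4 `COC(=O)[C@@H](CC(C)C)NC(=O)Cn1cc(C2=C(c3c[nH]c4ccccc34)C(=O)N(C)C2=O)c2ccccc21`: not yet measured

In a functional assay on A549 cells (Homo sapiens) for cytotoxicity, read by MTT assay, with a stated time of 24 h (a higher number here means a weaker inhibitor, a lower number a stronger inhibitor), compound 3 stands level with compound 2, as shown by a 1.5-fold higher number from compound 2 to compound 3 (0.17 log units; within the scatter). Compound 4 carries 1-(methoxycarbonyl)-3-methylbutyl in place of 2-(methoxycarbonyl)ethyl on an amide-type nitrogen. Within the data shown here, the closest precedent is the change between 1-(methoxycarbonyl)-2-methylbutyl of compound 1 and the group of compound 3, an at least 2.6-fold lower number from compound 1 to compound 3 (0.42 log units; beyond the scatter). Read backwards, that step suggests a higher number for the larger chain, and an at least 3.8-fold lower number from compound 1 to compound 2 (0.59 log units; beyond the scatter) also links compound 1 to the weak end. The expected step is therefore modest and upward: a 1.7-fold higher number from compound 3 to compound 4 (0.24 log units; within the scatter). Compound 4 is estimated at 65000 nM, with an expected range of 28000 nM to 100000 nM.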

Compound 4, half-maximal inhibitory concentration: > 100000 nM
Compound 4 ended at the assay's limit (the forecaster's own chance of this, stated with the estimate: 35%); middle value at least 1.5-fold (0.18 log units) from the limit.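

In this assay, the larger chain clearly weakens the compound: 1-(methoxycarbonyl)-3-methylbutyl in place of 2-(methoxycarbonyl)ethyl gives an at least 2.6-fold higher number from compound 3 to compound 4 (0.42 log units; beyond the scatter), and isobutyl in place of 1-hydroxyethyl gives an at least 3.8-fold higher number from compound 2 to compound 4 (0.59 log units; beyond the scatter). The values of compound 1, with sec-butyl, and compound 4, with isobutyl, are both limits and not numbers: the limit of > 100000 nM in this assay, at which 2 of the 4 values shown sit. Only compound 2 and compound 3, which carry neither group, keep readable values.

The step between the two limits cannot be read, so sec-butyl and isobutyl remain unranked. From the compounds shown here alone, how a carboxylic acid in place of the methyl ester, or an amine on the chain, would behave remains open.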